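Fluoro to chloro on the shared core of compound 2

This account rests on a few compounds, and the source may have more. Where it says the series, first, only, none or still open, it means among the compounds named here.

Measured so far:
compound 1, `O=C1c2ccccc2C(=O)N1c1nc(-c2ccccc2)cs1`, gives 43900 nM in a functional assay on PC-3 cells (Homo sapiens) for antiproliferative activity, read by MTT assay, with a stated time of 48 h; on this read-out lower numbers stand for stronger inhibition and higher numbers for weaker inhibition.
compound 2, `O=C1c2ccccc2C(=O)N1c1nc(-c2ccc(F)cc2)cs1`, gives 37200 nM in this assay.

On these two numbers compound 2 and compound 1 sit within the scatter of each other, as the step of a 1.2-fold lower number from compound 1 to compound 2 (0.07 log units; within the scatter) shows. Compound 3, `O=C1c2ccccc2C(=O)N1c1nc(-c2ccc(Cl)cc2)cs1`, differs from compound 2 by chloro in place of fluoro on an aromatic carbon. Among the compounds with values here, the only measured step that bears on this halogen position is a 1.2-fold lower number from compound 1 to compound 2 (0.07 log units; within the scatter), and it stayed within the scatter. No step beyond the scatter is therefore expected, a 1.2-fold lower number from compound 2 to compound 3 (0.07 log units; within the scatter). Compound 3 is estimated at 32000 nM, with a range from 12000 nM to 85000 nM.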

Compound 3, half-maximal inhibitory concentration: 44900 nM
Compound 3: the middle estimate sits 1.4-fold (0.15 log units) below what was measured; the range from low to high includes it.
By their numbers in this assay, from the lowest: compounds 2, 1 and 3 (each within the scatter of the next).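

In this assay the position on the six-membered aromatic ring now carries a second halogen: chloro in place of fluoro gives a 1.2-fold higher number from compound 2 to compound 3 (0.08 log units; within the scatter) and chloro in place of hydrogen gives a 1.0-fold higher number from compound 1 to compound 3 (0.01 log units; within the scatter) while both stay within the scatter. Hydrogen, fluoro and chloro at this position therefore cannot be told apart on these numbers. No measured finding is available that would account for this reading. The compounds shown leave open whether a group other than a halogen here, such as an amine or a carboxylic acid, would give a step beyond the scatter. They also leave open whether any change elsewhere on the shared core would do so.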